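The source may report more compounds than this note shows. Statements on the series, on what has been measured and on what is new or still open speak of the compounds shown alone.

Of the compounds shown here, two on one shared core have been measured so far. In a functional assay on MCF7 cells (Homo sapiens) for inhibition, read by sulforhodamine B assay, with a stated time of 48 h (a higher number here means a weaker inhibitor of growth, a lower number a stronger inhibitor of growth), compound 1 `COc1ccc2c(c1)NC(=O)CN2c1nc(Nc2cccc(C#N)c2)nc2ccccc12` gives 384 nM while compound 2 `COc1ccc2c(c1)NC(=O)CN2c1nc(NC2CC2)nc2ccccc12` gives 1.08 nM and so stands at the lower of the two numbers, the stronger inhibitor of growth of this pair. Among the compounds with values here, the one measured step is a 360-fold lower number from compound 1 to compound 2 (2.55 log units; beyond the scatter) and it came with cyclopropyl in place of 3-cyanophenyl on a nitrogen on an aromatic ring. Compound 3 `CCCCNc1nc(N2CC(=O)Nc3cc(OC)ccc32)c2ccccc2n1` differs from compound 2 at that same place, and the change is butyl in place of cyclopropyl on a nitrogen on an aromatic ring with butyl in place of cyclopropyl. Within the data shown here, only the step of a 360-fold lower number from compound 1 to compound 2 (2.55 log units; beyond the scatter) bears on this change, and it shows that the place can matter greatly in this assay for this pair. Among the measured compounds shown here, it does not compare a three-membered ring with an open chain, and no measured pair does. A much smaller move is therefore expected, towards a higher number. The estimate is a 5.6-fold higher number from compound 2 to compound 3 (0.74 log units; beyond the scatter) and remains uncertain. Compound 3 is expected at 6 nM in this assay with an estimated range from 1.2 nM to 40 nM.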

Compound 3, concentration for 50% growth inhibition: 7.88 nM
Estimate against measurement, compound 3: 1.3-fold (0.12 log units) below, and the stated range covers the measured number.
By their numbers in this assay, from the lowest: compound 2; then compound 3; then compound 1.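

In this assay, the step from a ring to an open chain is now measured, and it is far smaller than the earlier change at this position, with a 7.3-fold higher number from compound 2 to compound 3 (0.86 log units; beyond the scatter). Butyl also keeps most of the gain seen with cyclopropyl, giving a 49-fold lower number from compound 1 to compound 3 (1.69 log units; beyond the scatter), so among these three compounds both groups without an aromatic ring give lower numbers than 3-cyanophenyl, and no compound shown goes against this. Because the cyclopropyl to butyl change removes the ring and adds a carbon at once, the step cannot assign the difference to either alteration, and no measurement at hand offers a cause for it.

The compounds shown leave open whether the ring or the chain length matters more, which a propyl chain, an isopropyl group or a cyclobutyl ring in this place could help to separate. They also leave open how far this position extends to a longer chain such as hexyl, a chain carrying an amine, or a plain phenyl group without the nitrile.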